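Adding a Trifluoromethyl Group: Expected Effect on Skin-Cell Toxicity

The source may hold more compounds than are shown below. What is called first, only, known or untested is meant among the compounds shown, and "the series" means these compounds.

Compound 1 `Cc1cc(S(=O)(=O)/N=C(\N)n2nccc2-c2ccccc2)c(SCc2ccccc2)cc1Cl` was tested in an ADME assay on HaCaT cells (Homo sapiens) for cytotoxicity, read by MTT assay, with a stated time of 72 h (a lower number here means a stronger inhibitor, a higher number a weaker inhibitor), where compound 1 gives 18000 nM. Of the two numbers recorded so far this is the higher one; the nearest is compound 2 `Cc1cc(-c2ccccc2)n(/C(N)=N/S(=O)(=O)c2cc(C)c(Cl)cc2SCc2ccccc2)n1`, which in this assay gives 10000 nM, and the step of a 1.8-fold lower number from compound 1 to compound 2 (0.26 log units; within the scatter), adding a methyl group on an aromatic carbon, lies within the scatter. Compound 3 `Cc1cc(S(=O)(=O)/N=C(\N)n2nccc2-c2ccccc2)c(SCc2ccccc2C(F)(F)F)cc1Cl` differs from compound 1 by trifluoromethyl in place of hydrogen on an aromatic carbon. Among the compounds with values here, no measured step touches this part of the molecule; the only step available, from compound 1 to compound 2, changes a different ring and stays within the scatter. Nothing in these two numbers points toward a larger shift. Compound 3 is therefore expected to show a step of a 1.3-fold lower number from compound 1 to compound 3 (0.11 log units; within the scatter) that does not go beyond the scatter. The estimate for compound 3 in this assay is 14000 nM, within a range from 6000 nM to 35000 nM.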

Compound 3, half-maximal inhibitory concentration: 20000 nM
For compound 3 the middle estimate is 1.4-fold (0.15 log units) below the measured one; low and high end bracket the measured number.
By their numbers in this assay, from the lowest: compounds 2, 1 and 3 (each within the scatter of the next).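

Within the data shown here, compound 3 gives the first reading for a change on the benzylsulfanyl part of the molecule, and in this assay replacing benzylsulfanyl with (2-(trifluoromethyl)benzyl)sulfanyl gives a 1.1-fold higher number from compound 1 to compound 3 (0.05 log units; within the scatter) in this skin-cell test. At this one position, then, hydrogen can give way to trifluoromethyl with no shift that stands out from the ordinary spread of repeated measurements. No further measurement bears on why the number holds steady here.

From the compounds shown here alone, whether an amine, a carboxylic acid or a longer chain such as propyl at this same position would move the number beyond that spread remains open. Also open, going by these compounds, is whether trifluoromethyl would give a similar reading when combined with the added methyl group of compound 2.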